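The source may hold more compounds than are shown below. What is called first, only, known or untested is meant among the compounds shown, and "the series" means these compounds.

Compound 1 `CC(O)Cn1cnc2ncnc(N)c21` gives in an assay on CHO cells for displacement of a labelled ligand from adenosine receptor A1 (Homo sapiens) (on this read-out lower numbers stand for stronger inhibition and higher numbers for weaker inhibition), only a limit, > 100000 nM. Among the measured compounds shown here, compound 2 `CC(O)Cn1c(Br)nc2c(N)ncnc21` gives 2900 nM in this assay, the only numerical value shown. The other value, that of compound 1, is a limit of the assay (the limit of > 100000 nM in this assay, at which 1 of the 2 values shown sits). Compound 3 `C=CCCn1c(Br)nc2c(N)ncnc21` is not yet measured; it differs from compound 2 by allyl in place of 1-hydroxyethyl on a saturated chain carbon bound to an aromatic nitrogen. For the measured compounds named here, no measured step guides this change, so compound 3 is expected to stay close, with a step from compound 2 to compound 3 of a 1.0-fold higher number from compound 2 to compound 3 (0.01 log units; within the scatter) not beyond the scatter. Compound 3 is estimated at 3000 nM, between 800 nM and 12000 nM.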

Compound 3, inhibition constant: 4900 nM
Estimate against measurement, compound 3: 1.6-fold (0.21 log units) below, and the stated range covers the measured number.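

In this assay the place on a saturated chain carbon bound to an aromatic nitrogen takes allyl in place of 1-hydroxyethyl with a 1.7-fold higher number from compound 2 to compound 3 (0.23 log units; within the scatter) as the whole effect on the number. The hydrogen-bond donor and acceptor counted in 1-hydroxyethyl can thus go without a shift beyond the scatter, which compound 1 and compound 2 alone could not show. Nothing given here explains this step.

From the compounds shown here alone, whether an amine, a carboxylic acid or a longer chain at this place would leave the number equally unmoved stays open.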